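Chloromethylbenzyl purines: dropping the second ring chloro

A few compounds are considered here, and "the series" means these few. Any claim that something is new, unique, unknown or untested is made for them only; others in the source may bear on it.

Measured so far in a functional assay on UACC-257 cells (Homo sapiens) for cytotoxicity, read by sulforhodamine B assay, with a stated time of 48 h; a higher number here means a weaker inhibitor of growth, a lower number a stronger inhibitor of growth:
compound 1, `ClCc1cccc(Cn2cnc3c(Cl)nc(Cl)nc32)c1`, 1860 nM
compound 2, `Nc1nc(Cl)c2ncn(Cc3ccccc3CCl)c2n1`, 13200 nM
compound 3, `ClCc1ccc(Cn2cnc3ncnc(Cl)c32)cc1`, 1580 nM

Compound 1 holds the second highest number of the three. Its nearest neighbour is compound 3, whose value lies within the scatter of that of compound 1; compound 2 stands furthest away, with a markedly higher number, a gap beyond the scatter.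

Compound 4, `ClCc1cccc(Cn2cnc3c(Cl)ncnc32)c1`, differs from compound 1 in one place: hydrogen in place of chloro on an aromatic carbon. Among the compounds with values here, no measured pair in the set shows this change by itself, so the step cannot be read off the data. Given that compound 3, also carrying a single chloro on the core, gives 1580 nM, no step beyond the scatter is expected, and a 1.0-fold lower number from compound 1 to compound 4 (0.01 log units; within the scatter) is the estimated move. Compound 4 is estimated at 1800 nM, in a range from 800 nM to 4500 nM.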

Compound 4, concentration for 50% growth inhibition: 20400 nM
For compound 4 the middle estimate is 11-fold (1.05 log units) below the measured one; measured number above the stated range.
By their numbers in this assay, from the lowest: compounds 3 and 1 (each within the scatter of the next); then compounds 2 and 4 (each within the scatter of the next).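

In this assay hydrogen in place of chloro on this aromatic carbon, between two ring nitrogen atoms, gives an 11-fold higher number from compound 1 to compound 4 (1.04 log units; beyond the scatter) and marks the position as sensitive to this change. On this single pair, the chloro cannot be swapped for hydrogen without a large loss of growth inhibition. Nothing available explains the size of the step.

Going by these compounds, whether an amine, a methoxy or a bromo at this carbon would keep growth inhibition stays open. Also open, on these data alone, is whether the same step appears when the chloromethyl group sits elsewhere.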